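Returning a Nitrogen-Linked Group to the Carbonyl Carbon

The compounds below may be only part of what the source reports. "The series", "measured", "known", "first", "only" and "open" are said of these compounds alone.

Compound 2 `C#CC(C)OC(=O)c1ccc(C(CC)(CC)c2ccc(OCCC(O)(CC)CC)c(C)c2)n1CC` gives only a limit in a functional assay on MCF7 cells (Homo sapiens) for antiproliferative activity, read by MTT assay, with a stated time of 48 h (on this read-out higher numbers stand for weaker inhibition and lower numbers for stronger inhibition), namely > 50000 nM, sitting at the weaker edge of the values shown (the limit of > 50000 nM in this assay, at which 1 of the 2 values shown sits). Compound 1 `CCN(CC)CCNC(=O)c1ccc(C(CC)(CC)c2ccc(OCCC(O)(CC)CC)c(C)c2)n1CC` gives 550 nM in this assay. Going by the values given here, the one measured step that bears on the question is an at least 90-fold higher number from compound 1 to compound 2 (1.95 log units; beyond the scatter), a large loss. Compound 3 `CCn1c(C(=O)NC(CO)CCO)ccc1C(CC)(CC)c1ccc(OCCC(O)(CC)CC)c(C)c1` differs from compound 2 by a group of 7 heavy atoms (4 carbon, 1 nitrogen, 2 oxygen; no ring) in place of a group of 5 heavy atoms (4 carbon, 1 oxygen; no ring), on a carbonyl carbon, so the carbonyl carbon again carries a nitrogen-linked group, as in compound 1. A lower number is therefore expected for compound 3, with the expected step of an at least 10-fold lower number from compound 2 to compound 3 (1.00 log units; beyond the scatter), though its true size against a limit is uncertain. Compound 3 is estimated at 5000 nM, between 800 nM and 30000 nM.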

Compound 3, half-maximal inhibitory concentration: 31400 nM
Estimate against measurement, compound 3: 6.3-fold (0.80 log units) below; the measured number lies above the stated range.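

An amide link on the carbonyl carbon does not by itself keep the activity in this assay: with 3-hydroxy-1-(hydroxymethyl)propyl in place of 2-(diethylamino)ethyl on the amide-type nitrogen, the result is a 57-fold higher number from compound 1 to compound 3 (1.76 log units; beyond the scatter). Against the ester, the change gives only an at least 1.5-fold lower number from compound 2 to compound 3 (0.20 log units; that floor lies within the scatter), so the group on that nitrogen counts here, not the nitrogen link alone. Compound 2 stands at a limit of the assay, not at a number: the limit of > 50000 nM in this assay, at which 1 of the 3 values shown sits.

On these data alone, how a longer chain carrying the same diethylamino group would read remains open. So does a carboxylic acid on this carbonyl carbon.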